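Pyridin-4-yl in Place of 4-Chlorophenyl on the Ester Chain

A few compounds are considered here, and "the series" means these few. Any claim that something is new, unique, unknown or untested is made for them only; others in the source may bear on it.

Compound 1 `CC1=NC(C)=C(C(=O)O)C(c2cccc(Cl)c2)/C1=C(\O)OC/C=C/C1CCCCC1`: 3.7 nM
Compound 2 `CC1=NC(C)=C(C(=O)O)C(c2cccc(Cl)c2)/C1=C(\O)OC/C=C/c1ccc(Cl)cc1`: 5.8 nM

In a functional assay on thoracic aorta for inhibition of Voltage-gated L-type calcium channel (Rattus norvegicus) (on this read-out lower numbers stand for stronger inhibition and higher numbers for weaker inhibition), compound 1 gives 3.7 nM and compound 2 gives 5.8 nM. Compound 2 shows the higher of the two numbers, but its nearest neighbour compound 1 lies within the scatter. Compound 3 `CC1=NC(C)=C(C(=O)O)C(c2cccc(Cl)c2)/C1=C(\O)OC/C=C/c1ccncc1` differs from compound 2 by pyridin-4-yl in place of 4-chlorophenyl on a double-bonded chain carbon bound to a double-bonded chain carbon. Among the compounds with values here, the one measured step, a 1.6-fold higher number from compound 1 to compound 2 (0.20 log units; within the scatter), exchanged rings at the same place and stayed within the scatter, yet neither ring held a hetero atom, so it bears only loosely here. A modest weakening is expected, a 1.6-fold higher number from compound 2 to compound 3 (0.19 log units; within the scatter), with wide uncertainty. Compound 3 is estimated at 9 nM, within 3 nM to 30 nM.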

Compound 3, half-maximal inhibitory concentration: 320 nM
Compound 3: middle estimate off by 36-fold (1.55 log units), on the low side; the whole stated range lies below it.
By their numbers in this assay, from the lowest: compounds 1 and 2 (each within the scatter of the next); then compound 3.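

This position does not accept every ring alike: cyclohexyl and 4-chlorophenyl stay within the scatter of each other, but pyridin-4-yl brings much weaker inhibition (a 55-fold higher number from compound 2 to compound 3 (1.74 log units; beyond the scatter); an 86-fold higher number from compound 1 to compound 3 (1.94 log units; beyond the scatter)). Of the groups shown, only pyridin-4-yl has a hetero atom in its ring and a hydrogen-bond acceptor, and that difference travels with the loss. Nothing available explains the drop.

On these data alone, it remains open whether plain phenyl, pyridin-3-yl or a ring carrying an amine would stay close to compound 1 and compound 2 or fall toward compound 3.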